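Small change on the sulfonyl ring, moving from compound 2

The source may hold more compounds than are shown below. What is called first, only, known or untested is meant among the compounds shown, and "the series" means these compounds.

Compound 2 `O=C(c1ccccc1)c1cccc(NS(=O)(=O)c2ccccc2)c1` has the lower number of the two measured compounds: in an assay on CHO cells for binding affinity to integrin alpha-1 (Homo sapiens), read by WST assay, with a stated time of 2 h, tested at 50 uM (on this read-out higher numbers stand for more inhibition at the one concentration tested (going by the name of the read-out) and lower numbers for less inhibition), compound 2 gives 4%, whereas compound 1 `O=C(c1ccccc1)c1cccc(NS(=O)(=O)c2ccc(Cl)cc2Cl)c1` gives 69%. Within the data shown here, the single measured step, a number 65 percentage points lower from compound 1 to compound 2 (beyond the scatter), shows how much this assay can move when the ring on the sulfonyl sulfur changes. Compound 3 `Cc1ccc(S(=O)(=O)Nc2cccc(C(=O)c3ccccc3)c2)cc1` differs from compound 2 by methyl in place of hydrogen on an aromatic carbon. Among the measured compounds shown here, no measured step covers a methyl group here; the step from compound 1 to compound 2 concerned two chlorine atoms and is only a loose guide. Because a number 65 percentage points lower from compound 1 to compound 2 (beyond the scatter) shows that decorating this ring matters, a single methyl is expected to shift compound 3 upward by a small amount, a number 8 percentage points higher from compound 2 to compound 3 (within the scatter), likely near the scatter. Compound 3 is therefore estimated at 12%, within a range from 0% to 35%.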

Compound 3, a percentage reported as inhibition, at one concentration (the size of the read-out at that concentration, not a potency): 34%
The estimate for compound 3 lay 22 percentage points below the measured number; the range from low to high includes it.
By their numbers in this assay, from the lowest: compound 2; then compound 3; then compound 1.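

In this assay, a single methyl on the sulfonyl ring, para to a large group, is enough to move the read-out: the change gives a number 30 percentage points higher from compound 2 to compound 3 (beyond the scatter), so the gain seen earlier does not need two chlorine atoms. The methyl does not recover the whole of that gain, though, as replacing 2,4-dichlorophenyl with 4-methylphenyl still leaves a number 35 percentage points lower from compound 1 to compound 3 (beyond the scatter). Nothing measured here explains why either ring change has the effect it does.

The compounds shown leave open what a methoxy group, an ethyl chain or a single chlorine atom would give at this same place. They also leave open whether the methyl alone would give a similar gain at any other carbon of the ring.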